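Propyl Extension of the Side Chain and Partition

This account rests on a few compounds, and the source may have more. Where it says the series, first, only, none or still open, it means among the compounds named here.

Measured compounds:
Compound 1 `CCCCCc1cn(C/C=C(/C)CC/C=C(\C)CCC=C(C)C)nn1`, in a physicochemical assay for lipophilicity, measured as octanol-water partition (a lower number here means a more polar compound, a higher number a more lipophilic compound), compound 1 gives 7.5.
Compound 2 `CCCCCc1cn(CC=C(C)C)nn1`, in this assay compound 2 gives 3.46.
Compound 3 `CCCCCCCCc1cn(C/C=C(/C)CC/C=C(\C)CCC=C(C)C)nn1`, in this assay compound 3 gives 8.76.

Compound 3 differs from compound 1 by one change, (propyl in place of hydrogen on a saturated chain carbon, five bonds along the chain from an aromatic carbon). That change moved this assay by a number 1.26 log units higher from compound 1 to compound 3 (beyond the scatter), a step well beyond the scatter. Compound 2 and compound 1 share a core but differ in a larger part of the molecule; how the two cores differ is not broken down here, and compound 2 stands lowest of the three values, with compound 1 nearest and compound 3 furthest.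

Compound 4 `CCCCCCCCc1cn(CC=C(C)C)nn1` is not yet measured. It differs from compound 2 by propyl in place of hydrogen on a saturated chain carbon, five bonds along the chain from an aromatic carbon, the same change that turns compound 1 into compound 3, at a place described in the same words. The step from compound 2 to compound 4 is therefore expected to be about a number 1.26 log units higher from compound 2 to compound 4 (beyond the scatter), because the earlier step was a number 1.26 log units higher from compound 1 to compound 3 (beyond the scatter). Compound 4 is accordingly estimated at 4.72, with a likely range from 4.3 to 5.2.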

Compound 4, partition coefficient: 4.92
The estimate for compound 4 lay 0.20 log units below the measured number; measured number inside the range.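

Carried to the core of compound 2, propyl in place of hydrogen on a saturated chain carbon, five bonds along the chain from an aromatic carbon, gave in this assay a number 1.46 log units higher from compound 2 to compound 4 (beyond the scatter), against a number 1.26 log units higher from compound 1 to compound 3 (beyond the scatter) on the core of compound 1. The change therefore went the same way and was large on both cores, although those cores differ in a larger part of the molecule, and this shows that the step carried over between these two cores in this one assay. It does not show that the step would carry to any further core, and no measurement shown here explains the result.

What the compounds shown leave open is whether a similar step would follow from a longer chain in place of the propyl, or what an amine or a carboxylic acid there would do. Any reading in another assay also remains open, since the two steps rest on partition alone.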